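Trimming a Hexyl Chain: Expecting Little Change in Growth Inhibition

A few compounds are considered here, and "the series" means these few. Any claim that something is new, unique, unknown or untested is made for them only; others in the source may bear on it.

Compound 1 `CCCCCCc1cc2c(=O)n(CCCSc3nc(-c4cc(OC)c(OC)c(OC)c4)c(C#N)c(=O)[nH]3)cnc2s1` gives 67 ug/mL in an ADME assay on HeLa cells (Homo sapiens) for inhibition, read by MTT assay; a higher number here means a weaker inhibitor of growth, a lower number a stronger inhibitor of growth.
Compound 2 `COc1cc(-c2[nH]c(=S)[nH]c(=O)c2C#N)cc(OC)c1OC` gives 63.7 ug/mL in this assay.

Among the compounds with values here, compound 1 and compound 2 differ in more than one place, so no single step connects them; their two numbers lie within the usual scatter of each other, and neither can be called the stronger or weaker inhibitor of growth. Compound 3 `CCCc1cc2c(=O)n(CCCSc3nc(-c4cc(OC)c(OC)c(OC)c4)c(C#N)c(=O)[nH]3)cnc2s1` differs from compound 1 by hydrogen in place of propyl on a saturated chain carbon, three bonds along the chain from an aromatic carbon. Within the data shown here, with no step between measured compounds to guide it, this change is expected to move the number little, if at all beyond the scatter. Compound 3 is expected to give 70 ug/mL, within 35 ug/mL to 140 ug/mL, an expected step of a 1.0-fold higher number from compound 1 to compound 3 (0.02 log units; within the scatter).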

Compound 3, concentration for 50% growth inhibition: 52.5 ug/mL
The estimate for compound 3 lay 1.3-fold (0.12 log units) above the measured number; measured number inside the range.
By their numbers in this assay, from the lowest: compounds 3, 2 and 1 (each within the scatter of the next).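

Going from hexyl to propyl in this assay gives a 1.3-fold lower number from compound 1 to compound 3 (0.11 log units; within the scatter) and this is the first step that can be read at this position. On this single step, the outer part of the hexyl chain can go without a change in growth inhibition that stands clear of the scatter. Nothing available explains this result. On these data alone, it remains open whether a longer chain than hexyl would move the number beyond the scatter. The same goes for an amine or a carboxylic acid in place of propyl on this saturated chain carbon.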